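Removing the Core Methyl of Compound 3

The source may report more compounds than this note shows. Statements on the series, on what has been measured and on what is new or still open speak of the compounds shown alone.

Compound 1 `COc1ccccc1-c1cc(O)c2ccc(C)nc2n1` gives in a functional assay on PC-3 cells (Homo sapiens) (a lower number here means a stronger inhibitor of growth, a higher number a weaker inhibitor of growth), the value > 100000 nM, which is a limit of the assay and not a number.
Compound 2 `COc1ccccc1-c1cc(O)c2cccnc2n1` gives in this assay 29500 nM.
Compound 3 `COc1cccc(-c2cc(O)c3c(C)ccnc3n2)c1` gives in this assay 26.3 nM.

From compound 1 to compound 2 the change is hydrogen in place of methyl on an aromatic carbon, and the step is an at least 3.3-fold lower number from compound 1 to compound 2 (0.53 log units; beyond the scatter). That step starts from a limit (the limit of > 100000 nM in this assay, at which 1 of the 3 values shown sits).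

Compound 3 has the same atoms as compound 1, joined differently; the difference between the two cores is not broken down here.

Compound 4 `COc1cccc(-c2cc(O)c3cccnc3n2)c1` differs from compound 3 by hydrogen in place of methyl on an aromatic carbon. This is the same kind of change as from compound 1 to compound 2, not the same: there the methyl sat next to the ring nitrogen, meta to a fused ring, para to a fused ring; here it sits ortho to a fused ring, meta to a fused ring, opposite the ring nitrogen.

For compound 4 a step of a 1.5-fold higher number from compound 3 to compound 4 (0.18 log units; within the scatter) is expected, resting on the step of an at least 3.3-fold lower number from compound 1 to compound 2 (0.53 log units; beyond the scatter) while allowing for the different place. Compound 4 is estimated at 40 nM, between 10 nM and 200 nM.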

Compound 4, concentration for 50% growth inhibition: 93.3 nM
For compound 4 the middle estimate is 2.3-fold (0.37 log units) below the measured one; low and high end bracket the measured number.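

In this assay, putting hydrogen in place of methyl on this aromatic carbon gives a 3.5-fold higher number from compound 3 to compound 4 (0.55 log units; beyond the scatter), so on this core the methyl-bearing compound is the stronger inhibitor of growth. The same kind of change moved the number the opposite way on the other core, so its effect does not carry over with one direction between these two cores: the same change on two cores in this assay, an at least 3.3-fold lower number (0.53 log units; beyond the scatter) from compound 1 to compound 2 and a 3.5-fold higher number (0.55 log units; beyond the scatter) from compound 3 to compound 4, at least 12-fold (1.08 log units) apart, beyond the scatter of two such steps Compound 1 gives only a limit of the assay and not a number, so the full size of the earlier step is unknown, and these steps do not show why the two cores differ: the limit of > 100000 nM in this assay, at which 1 of the 4 values shown sits.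

As far as these compounds go, what an ethyl group or a chlorine atom on that aromatic carbon would give remains open. So does how the change behaves on further cores.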